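A few compounds are considered here, and "the series" means these few. Any claim that something is new, unique, unknown or untested is made for them only; others in the source may bear on it.

Working notes on the series. The shared core carries an aryl sulfonate ester with an amide on the sulfonyl-bearing ring. Compound 3 `CCCCCC(=O)Nc1ccc(S(=O)(=O)Oc2ccccc2I)cc1` is measured in a functional assay on HT-1080 cells (Homo sapiens) for antiproliferative activity, read by sulforhodamine B assay, with a stated time of 48 h (on this read-out lower numbers stand for stronger inhibition and higher numbers for weaker inhibition), at 9600 nM. Compound 2 `CCCCCC(=O)Nc1ccc(S(=O)(=O)Oc2ccccc2C(C)C)cc1` gives 6300 nM in this assay, and the step of a 1.5-fold higher number from compound 2 to compound 3 (0.18 log units; within the scatter) sits within the scatter, so compounds 2 and 3 are not separated on this read-out. Compound 1 `CC(C)c1ccccc1OS(=O)(=O)c1cccc(NC(=O)CCCl)c1` gives 8200 nM in this assay, and the three values thus lie close together.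

Compound 4 `O=C(CCCl)Nc1ccc(S(=O)(=O)Oc2ccccc2I)cc1` is not yet measured. It differs from compound 3 by chloro in place of propyl on a saturated chain carbon, two bonds along the chain from a carbonyl carbon. For the measured compounds named here, no measured pair isolates this change: compound 1 carries the chloro chain but with a different amide placement and a different group on the ester ring, so its value is not a clean comparison. Going by the values given here, the one measured step, a 1.5-fold higher number from compound 2 to compound 3 (0.18 log units; within the scatter), concerns the ester ring and is within the scatter. Without a bearing step, no change beyond the scatter is expected, and compound 4 is estimated at 9000 nM (range 4000 nM to 20000 nM) in this assay, an expected step of a 1.1-fold lower number from compound 3 to compound 4 (0.03 log units; within the scatter).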

Compound 4, half-maximal inhibitory concentration: 4200 nM
For compound 4 the middle estimate is 2.1-fold (0.33 log units) above the measured one, within the range that was stated.
By their numbers in this assay, from the lowest: compounds 4, 2, 1 and 3 (each within the scatter of the next, the first and the last beyond it).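

Chloro in place of propyl on a saturated chain carbon, two bonds along the chain from a carbonyl carbon, gives a 2.3-fold lower number from compound 3 to compound 4 (0.36 log units; beyond the scatter) in this assay and is the first step in the series beyond the scatter, though a modest one. For the compounds shown here, this chain position therefore moves the read-out with the ester ring held constant, while the one earlier step, a 1.5-fold higher number from compound 2 to compound 3 (0.18 log units; within the scatter) on the ester ring, stays within the scatter. No measurement on these compounds points to a cause for this step.

With pentyl giving way to 2-chloroethyl, the compounds shown do not separate the chloro from the shortening of the chain, and a plain ethyl chain or an amine at the same place would be needed to tell the two apart. As far as these compounds go, whether the same step holds with isopropyl on the ester ring also stays open.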